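A Nitrile Enters the Phenyl-Bearing Arm of Compound 1

A few compounds are considered here, and "the series" means these few. Any claim that something is new, unique, unknown or untested is made for them only; others in the source may bear on it.

Compound 1 `Cc1ccc2cnc(-c3ccccc3)nc2n1` gives 2700 nM in a functional assay on CHO cells for antagonist activity at metabotropic glutamate receptor 5 (Rattus norvegicus), read by FLIPR and calcium flux (on this read-out lower numbers stand for stronger inhibition and higher numbers for weaker inhibition), the highest of the two numbers shown. Compound 3 `Cc1cccc(-c2ncc3ccc(C)nc3n2)c1` gives 53 nM in this assay, far lower. Compound 2 `COc1ccccc1-c1ncc2ccc(C)nc2n1` in this assay reaches only the limit > 30000 nM, a limit of the assay and not a number (the limit of > 30000 nM in this assay, at which 1 of the 3 values shown sits). Compound 4 `Cc1ccc2cnc(-c3ccc(C#N)cc3)nc2n1` differs from compound 1 by cyano in place of hydrogen on an aromatic carbon. Among the compounds with values here, two measured steps bear on this change: a 51-fold lower number from compound 1 to compound 3 (1.71 log units; beyond the scatter) and an at least 11-fold higher number from compound 1 to compound 2 (1.04 log units; beyond the scatter), a large step in each direction on the same ring, but neither places its group where the cyano enters, so the direction stays open. The expected step is a 1.8-fold lower number from compound 1 to compound 4 (0.26 log units; within the scatter). Compound 4 is therefore estimated at 1500 nM, with a range from 300 nM to 8000 nM.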

Compound 4, half-maximal inhibitory concentration: > 30000 nM
Compound 4 ended at the assay's limit (the forecaster's own chance of this, stated with the estimate: 10%); middle value at least 20-fold (1.30 log units) away from the limit.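

With cyano on the aromatic carbon para to a large group, the direction left open before is settled for this position, and it is upward: an at least 11-fold higher number from compound 1 to compound 4 (1.04 log units; beyond the scatter). In this assay, going by these compounds, compound 4 gives > 30000 nM, which is a limit of the assay and not a number, so the true size of the step remains unknown. Compound 4 now shares that limit with compound 2: the limit of > 30000 nM in this assay, at which 2 of the 4 values shown sit.

The compounds shown leave open whether an amine or a carboxylic acid at this position would also end at the limit. They also leave open how cyano would behave on another carbon of the same ring.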